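Acyl side-chain variation on a shared core: compound 4

This account rests on a few compounds, and the source may have more. Where it says the series, first, only, none or still open, it means among the compounds named here.

Measured so far in a functional assay on PBMC cells (Homo sapiens) for inhibition; a lower number here means a stronger inhibitor, a higher number a weaker inhibitor:
compound 1 `CC(C)C[C@H](N)C(=O)NS(=O)(=O)OC[C@H]1O[C@@H](n2cnc3c(N)ncnc32)[C@H](O)[C@@H]1O`: 1100 nM
compound 2 `Nc1ncnc2c1ncn2[C@@H]1O[C@H](COS(=O)(=O)NC(=O)[C@@H]2CCN2)[C@@H](O)[C@H]1O`: 600 nM
compound 3 `Nc1ncnc2c1ncn2[C@@H]1O[C@H](COS(=O)(=O)NC(=O)[C@@H]2CCCN2)[C@@H](O)[C@H]1O`: 700 nM

Compound 3 gives the second highest of the three numbers; its nearest neighbour lies at a 1.2-fold higher number from compound 2 to compound 3 (0.07 log units; within the scatter) and its furthest at a 1.6-fold lower number from compound 1 to compound 3 (0.20 log units; within the scatter), both within the scatter. Compound 4 `N=C(N)NCCC[C@H](N)C(=O)NS(=O)(=O)OC[C@H]1O[C@@H](n2cnc3c(N)ncnc32)[C@H](O)[C@@H]1O` differs from compound 3 by a group of 9 heavy atoms (5 carbon, 4 nitrogen; no ring) in place of a group of 5 heavy atoms (4 carbon, 1 nitrogen; one five-membered non-aromatic ring with 1 hetero atom), on a carbonyl carbon. The step that bears on this is the open-chain to ring change a 1.6-fold lower number from compound 1 to compound 3 (0.20 log units; within the scatter), within the scatter, as was the related step of a 1.8-fold lower number from compound 1 to compound 2 (0.26 log units; within the scatter). Returning from a ring to an open chain on the carbonyl carbon is therefore expected to stay within the scatter, so the step of a 1.1-fold higher number from compound 3 to compound 4 (0.06 log units; within the scatter) is estimated as no step beyond it. In this assay compound 4 is expected near 800 nM, with a range of 300 nM to 2500 nM.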

Compound 4, half-maximal inhibitory concentration: 1000 nM
The estimate for compound 4 lay 1.3-fold (0.10 log units) below the measured number; the range from low to high includes it.
By their numbers in this assay, from the lowest: compounds 2, 3, 4 and 1 (each within the scatter of the next).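

In this assay, the open chain of compound 4 on the carbonyl carbon does not separate from the five-membered ring (a 1.4-fold higher number from compound 3 to compound 4 (0.15 log units; within the scatter)) or the four-membered ring (a 1.7-fold higher number from compound 2 to compound 4 (0.22 log units; within the scatter)). The replacement of one group by another on a saturated chain carbon also stays within the scatter (a 1.1-fold lower number from compound 1 to compound 4 (0.04 log units; within the scatter)), so all four side chains remain unseparated. As far as these compounds go, whether a carboxylic acid or a longer chain here would also stay within the scatter remains open. Nothing available bears on the cause of these steps.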